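A few compounds are considered here, and "the series" means these few. Any claim that something is new, unique, unknown or untested is made for them only; others in the source may bear on it.

Measured so far:
compound 1, `Cn1c(-c2ccc(NC(=O)CSc3nc4cc(Cl)ccc4o3)cc2)nc(-c2ccccc2)c1-c1ccccc1`, 40% in a functional assay on MCF7 cells (Homo sapiens) for cytotoxicity, read by MTT assay, with a stated time of 24 h, tested at 16 ug/mL; on this read-out higher numbers stand for a stronger effect at the one concentration tested and lower numbers for a weaker effect
compound 2, `Cn1ccnc1SCC(=O)Nc1ccc(-c2nc(-c3ccccc3)c(-c3ccccc3)n2C)cc1`, 32.4% in this assay

Among the compounds with values here, compound 2 gives the lower of the two numbers measured so far, but the only step between them, a number 7.6 percentage points lower from compound 1 to compound 2 (within the scatter), lies within the scatter, so the two compounds cannot be told apart on this assay. That step swapped one ring for another on the sulfur and left the rest of the molecule untouched.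

Compound 3, `CCN1CCN(CC(=O)Nc2ccc(-c3nc(-c4ccccc4)c(-c4ccccc4)n3C)cc2)CC1`, is not yet measured. It differs from compound 2 by 4-ethylpiperazin-1-yl in place of (1-methyl-1H-imidazol-2-yl)sulfanyl on a saturated chain carbon bound to a carbonyl carbon. Within the data shown here, this change removes the sulfur link altogether and brings in a saturated ring, which is a larger departure than the ring swap seen in the one measured step. That step, a number 7.6 percentage points lower from compound 1 to compound 2 (within the scatter), bears on the new change only loosely, since it kept the sulfur and the chain intact, and it showed nothing beyond the scatter. Nothing in the measured pair points to a shift in either direction, so the expected step from compound 2 to compound 3 is a number 0.4 percentage points lower from compound 2 to compound 3 (within the scatter), with a wide range to reflect the missing precedent. Compound 3 is therefore estimated at 32%, between 12% and 55%.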

Compound 3, a percentage reported as activity, at one concentration (the size of the read-out at that concentration, not a potency): 32.8%
Compound 3: the middle estimate sits 0.8 percentage points below what was measured; measured number inside the range.
By their numbers in this assay, from the lowest: compounds 2, 3 and 1 (each within the scatter of the next).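

In this assay, the place on a saturated chain carbon bound to a carbonyl carbon now carries a group with no sulfur link and a non-aromatic ring, and a number 0.4 percentage points higher from compound 2 to compound 3 (within the scatter) still lies within the scatter for 4-ethylpiperazin-1-yl in place of (1-methyl-1H-imidazol-2-yl)sulfanyl. The same holds against the other sulfur-linked group, as a number 7.2 percentage points lower from compound 1 to compound 3 (within the scatter) also lies within the scatter for 4-ethylpiperazin-1-yl in place of (5-chloro-1,3-benzoxazol-2-yl)sulfanyl. The earlier pair had compared only aromatic rings on a sulfur, so this result extends the finding of no readable difference to a much less similar group, though no evidence is available to explain this outcome.

The compounds shown leave open whether a morpholin-4-yl group, a carboxylic acid or a longer chain in place of the saturated chain carbon would give a step beyond the scatter. They also leave open what the ethyl group of 4-ethylpiperazin-1-yl contributes and, with a single concentration read, how these compounds compare in potency.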